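Two amides on a shared core, and a third to come

The compounds below may be only part of what the source reports. "The series", "measured", "known", "first", "only" and "open" are said of these compounds alone.

Compound 1 `CCCN(CC[C@H]1CC[C@H](NC(=O)/C=C/c2cccc(Cl)c2)CC1)[C@H]1CCc2nc(N)sc2C1`: 1.2 nM
Compound 2 `CCCN(CC[C@H]1CC[C@H](NC(=O)c2cccc3cnccc23)CC1)[C@H]1CCc2nc(N)sc2C1`: 5.9 nM

In an assay on brain for displacement of a labelled ligand from D(3) dopamine receptor (Rattus norvegicus) (a higher number here means a weaker inhibitor, a lower number a stronger inhibitor), compound 1 gives 1.2 nM and compound 2 gives 5.9 nM. Among the measured compounds shown here, compound 2 thus stands at the higher of the two numbers, and the gap to compound 1 is the single step measured: a 4.9-fold higher number from compound 1 to compound 2 (0.69 log units; beyond the scatter). Compound 3 `CCCN(CC[C@H]1CC[C@H](NC(=O)c2ccccc2-n2cccn2)CC1)[C@H]1CCc2nc(N)sc2C1` keeps everything of compound 2 except the group on the carbonyl carbon: 2-(1H-pyrazol-1-yl)phenyl in place of isoquinolin-5-yl on a carbonyl carbon. For the measured compounds named here, the one measured step exchanges an aromatic group for an ethenyl-linked one, so it bears only loosely on an exchange of one aromatic group for another; it shows that the amide substituent can shift this assay by a modest amount. Compound 3 is therefore expected to sit near compound 2, with a step of a 1.4-fold higher number from compound 2 to compound 3 (0.13 log units; within the scatter) that may not exceed the scatter. The estimate for compound 3 in this assay is 8 nM, with a range from 2 nM to 30 nM.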

Compound 3, inhibition constant: 2 nM
Compound 3: the middle estimate sits 4.0-fold (0.60 log units) above what was measured; the range from low to high includes it.
By their numbers in this assay, from the lowest: compounds 1 and 3 (each within the scatter of the next); then compound 2.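

In this assay, the exchange on the carbonyl carbon gives a 3.0-fold lower number from compound 2 to compound 3 (0.47 log units; beyond the scatter), so replacing one aromatic group with another at this place can move the number beyond the scatter, which the earlier step from an ethenyl-linked group could not show. The comparison with the ethenyl-linked amide gives a 1.7-fold higher number from compound 1 to compound 3 (0.22 log units; within the scatter), which leaves 2-(1H-pyrazol-1-yl)phenyl and 2-(3-chlorophenyl)ethenyl indistinguishable in this assay, so among these three compounds a low number does not depend on the ethenyl link. No measurement here offers an explanation for these differences.

The compounds shown leave open whether the pyrazole ring itself matters, since an unsubstituted phenyl group on the same carbonyl carbon does not appear among them. They also leave open how an amine or a carboxylic acid on the phenyl ring in place of the pyrazole would read.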